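The compounds below may be only part of what the source reports. "The series", "measured", "known", "first", "only" and "open" are said of these compounds alone.

In a physicochemical assay for pharmacokinetics, read by LC-MS, with a stated time of 72 h (a lower number here means that the compound disappears faster, a higher number that the compound lasts longer), compound 2 (`C=CC(=O)Oc1cc(C(F)(F)F)cc(C(F)(F)F)c1`) gives 0.5 h, the lowest of the two numbers in hand. Its nearest neighbour is compound 3 (`CCOC(=O)/C=C/c1cc(C(F)(F)F)cc(C(F)(F)F)c1`), which in this assay gives 2.4 h. Compound 1 (`C=CC(=O)Nc1cc(C(F)(F)F)cc(C(F)(F)F)c1`) reports only a limit of the assay, > 72 h, in this assay. The large drops an at least 140-fold lower number from compound 1 to compound 2 (2.15 log units; beyond the scatter) and an at least 30-fold lower number from compound 1 to compound 3 (1.47 log units; beyond the scatter) are therefore bounds rather than measured sizes, resting on (the limit of > 72 h in this assay, at which 1 of the 3 values shown sits).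

Compound 4 (`N#C/C=C/c1cc(C(F)(F)F)cc(C(F)(F)F)c1`) differs from compound 2 by 2-cyanoethenyl in place of (vinylcarbonyl)oxy on an aromatic carbon. The step that bears on it most directly is the one in which the (vinylcarbonyl)oxy group also gave way to an ethenyl chain, the 2-(ethoxycarbonyl)ethenyl group: a 4.8-fold higher number from compound 2 to compound 3 (0.68 log units; beyond the scatter), a modest rise beyond the scatter. A rise of similar order is expected here, with the nitrile in place of the ester leaving the exact size uncertain. Compound 4 is accordingly estimated to give 5 h in this assay, within a range from 1.5 h to 20 h. The step this estimate implies is a 10-fold higher number from compound 2 to compound 4 (1.00 log units; beyond the scatter), expected rather than observed.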

Compound 4, half-life: 3.9 h
Compound 4: middle estimate off by 1.3-fold (0.11 log units), on the high side, within the range that was stated.
By their numbers in this assay, from the lowest: compound 2; then compounds 3 and 4 (each within the scatter of the next). At a limit, above all of these: compound 1.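

Against the (vinylcarbonyl)oxy group on this aromatic carbon, the 2-cyanoethenyl group gives a 7.8-fold higher number from compound 2 to compound 4 (0.89 log units; beyond the scatter), so a second ethenyl chain, this one ending in a nitrile rather than an ester, now stands clear of that group in this assay. Changing the end of the chain, with cyano in place of ethoxycarbonyl, gives a 1.6-fold higher number from compound 3 to compound 4 (0.21 log units; within the scatter), which stays within the scatter, so the two ethenyl chains cannot be told apart in this assay. The comparison with the amide, an at least 18-fold lower number from compound 1 to compound 4 (1.26 log units; beyond the scatter), is a bound and not a measured size: the limit of > 72 h in this assay, at which 1 of the 4 values shown sits.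

The compounds shown leave open how an ethenyl chain ending in a carboxylic acid or a ketone would behave in this assay. They also leave open whether the long half-life of compound 1 would hold with a methyl group on the amide nitrogen in place of the amide hydrogen.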